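Changing the Aryl Group on a Piperazine Ring: Compound 4

The source may hold more compounds than are shown below. What is called first, only, known or untested is meant among the compounds shown, and "the series" means these compounds.

Compound 1, `Nc1scc(CN2CCN(c3ccc(Cl)cc3Cl)CC2)c1C(=O)c1ccc(Cl)cc1`, gives 2%.
Compound 2, `Nc1scc(CN2CCN(c3cc(Cl)cc(Cl)c3)CC2)c1C(=O)c1ccc(Cl)cc1`, gives -1%.
Compound 3, `Nc1scc(CN2CCN(c3ccc(F)cc3Cl)CC2)c1C(=O)c1ccc(Cl)cc1`, gives 6.1%.

These three values come from a functional assay on CHO cells with adenosine receptor A1 (Homo sapiens) as the target, read by cAMP accumulation and immunoassay, with a stated time of 6 min, tested at 0.01 uM; on this read-out higher numbers stand for a weaker effect at the one concentration tested and lower numbers for a stronger effect. All three numbers lie close to zero, so none of the compounds shows a clear effect at the single concentration used. Among the three numbers compound 3 has the highest, yet neither gap reaches beyond the usual scatter: a number 4.1 percentage points higher from compound 1 to compound 3 (within the scatter) and a number 7.1 percentage points higher from compound 2 to compound 3 (within the scatter). The remaining step, a number 3 percentage points lower from compound 1 to compound 2 (within the scatter), is likewise within the scatter.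

Compound 4, `COc1ccc(N2CCN(Cc3csc(N)c3C(=O)c3ccc(Cl)cc3)CC2)cc1`, has not yet been measured in this assay. It differs from compound 3 in one place: 4-methoxyphenyl in place of 2-chloro-4-fluorophenyl on an amine nitrogen in a ring. Among the measured compounds shown here, none of the measured steps involves a methoxy group; the measured steps only exchange chloro and fluoro substituents and move them around the ring, and none of them produced a shift beyond the scatter. For the measured compounds named here, the change to compound 4 therefore has no direct precedent here, and the only guide is that three different aryl groups on this ring nitrogen all gave near-zero numbers.

On that basis no step beyond the scatter is expected from compound 3 to compound 4, a number 3.1 percentage points lower from compound 3 to compound 4 (within the scatter). Compound 4 is estimated to give 3%, in a range from -9% to 15%.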

Compound 4, a percentage reported as activity, at one concentration (the size of the read-out at that concentration, not a potency): -1.2%
For compound 4 the middle estimate is 4.2 percentage points above the measured one, and the stated range covers the measured number.
By their numbers in this assay, from the lowest: compounds 4, 2, 1 and 3 (each within the scatter of the next).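

Among the compounds shown here, compound 4 takes the change on this ring nitrogen further than the earlier compounds did. Its 4-methoxyphenyl carries a methoxy group and no halogen, and it adds one hydrogen-bond acceptor while keeping the same count of heavy atoms as the group it replaces. Even so, this assay shows a number 7.3 percentage points lower from compound 3 to compound 4 (within the scatter) and a number 0.2 percentage points lower from compound 2 to compound 4 (within the scatter) and a number 3.2 percentage points lower from compound 1 to compound 4 (within the scatter), so this aryl group cannot be told apart from any of the three halogen-bearing ones at this one concentration, and the earlier finding now extends beyond exchanges of chloro and fluoro. Nothing at hand explains why the read-out stays so close across these aryl groups.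

As far as these compounds go, all four compounds keep a phenyl ring on this nitrogen, so it remains open what a cyclohexyl ring, a longer alkyl chain or a simple acetyl group would do there, or what an amine or a carboxylic acid on the phenyl ring would do. With only one concentration shown, it also remains open whether these compounds would separate at higher concentrations.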